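Piperazine in Place of tert-Butyl: Expected Cytotoxicity

This account rests on a few compounds, and the source may have more. Where it says the series, first, only, none or still open, it means among the compounds named here.

Of the compounds shown here, three have been tested in an ADME assay on THP-1 cells (Homo sapiens) for cytotoxicity, read by resazurin assay, with a stated time of 72 h; on this read-out lower numbers stand for higher toxicity in this test and higher numbers for lower toxicity in this test. Compound 1 `CC(C)(C)c1ccc(C(=O)/C=C/c2ccc([N+](=O)[O-])o2)cc1` gives only a limit of the measurement, > 50000 nM, so its true figure is not known. Compound 2 `CCCCc1ccc(C(=O)/C=C/c2ccc([N+](=O)[O-])s2)cc1` gives 17100 nM in this assay. Compound 3 `CN(C)c1ccc(/C=C/C(=O)c2ccc(-c3ccccc3)cc2)cc1` again reaches only a limit, > 50000 nM. Among the compounds with values here, compound 1 thus stands together with compound 3 at the limit of > 50000 nM in this assay, at which 2 of the 3 values shown sit, while compound 2 is the one compound with an actual number.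

Compound 4 `O=C(/C=C/c1ccc([N+](=O)[O-])o1)c1ccc(N2CCNCC2)cc1` has not yet been measured. It differs from compound 1 by piperazin-1-yl in place of tert-butyl on an aromatic carbon. Within the data shown here, no two measured compounds differ in a single place, so the size of such a change cannot be read from the data here. The step from compound 1 to compound 4 is expected to be an at least 1.2-fold lower number from compound 1 to compound 4 (0.09 log units; that floor lies within the scatter), meaning no clear shift beyond the usual scatter. Compound 4 is expected to give about 40000 nM, within a range from 15000 nM to 100000 nM, with a fair chance that only a limit is reported once more.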

Compound 4, half-maximal cytotoxic concentration: > 50000 nM
Compound 4: only a limit was reported; the forecaster's own chance of this, stated with the estimate: 55%; at least 1.2-fold (0.09 log units) between middle value and limit.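

In this assay, compound 1 and compound 4 both give only a limit, so no step between them can be read: the limit of > 50000 nM in this assay, at which 3 of the 4 values shown sit.

The compounds shown leave open the true figures of compound 1 and compound 4, and so whether piperazin-1-yl in place of tert-butyl changes this read-out at all.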